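This account rests on a few compounds, and the source may have more. Where it says the series, first, only, none or still open, it means among the compounds named here.

Working notes on the series.

Compound 1 `CC(C)(C)OC(=O)N[C@@H](CCCCS)C(=O)NC1CCCC1` gives, in an assay on isolated protein for inhibition of protein deacetylase HDAC6 (Homo sapiens), read by fluorescence, tested at 1 uM (on this read-out lower numbers stand for less inhibition and higher numbers for more inhibition at the one concentration tested (going by the name of the read-out)), 50%. Compound 2 `CC(C)(C)OC(=O)N[C@@H](CCCCCC(=O)O)C(=O)NC1CCCC1` gives in this assay 45%, the lower of the two numbers seen so far; its nearest neighbour is compound 1, and the gap a number 5 percentage points lower from compound 1 to compound 2 (within the scatter) lies within the scatter. The next compound, compound 3 `CC(C)(C)OC(=O)N[C@@H](CCCCCCS)C(=O)NC1CCCC1`, differs from compound 2 by sulfanylmethyl in place of carboxy on a saturated chain carbon, six bonds along the chain from an amide-type nitrogen and a carbonyl carbon. Within the data shown here, the only step that bears on this change is the one from compound 1 to compound 2, which swapped a sulfanyl for a carboxymethyl and moved the number by a number 5 percentage points lower from compound 1 to compound 2 (within the scatter), not beyond the scatter. Compound 3 puts a sulfur back at the end of a chain, so no step beyond the scatter is expected; the estimate is a number 5 percentage points higher from compound 2 to compound 3 (within the scatter) in this assay. Compound 3 is therefore expected to give 50% in this assay, with a range from 30% to 70%.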

Compound 3, a percentage reported as inhibition, at one concentration (the size of the read-out at that concentration, not a potency): 60%
Beside the measured number, compound 3's estimate is 10 percentage points below it; measured number inside the range.
By their numbers in this assay, from the lowest: compounds 2, 1 and 3 (each within the scatter of the next, the first and the last beyond it).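

Carboxy to sulfanylmethyl at this place, six bonds along the chain from an amide-type nitrogen and a carbonyl carbon, gives a number 15 percentage points higher from compound 2 to compound 3 (beyond the scatter) in this assay and is the first step in the series to pass the scatter. The two sulfur-ended chains stay unresolved, since 2-sulfanylethyl in place of sulfanyl gives a number 10 percentage points higher from compound 1 to compound 3 (within the scatter) and so shows no effect of chain length on its own. No data on hand account for the step from carboxy to sulfanylmethyl.

Still open, on these data alone, is whether a longer chain ending in sulfanyl would extend the step or leave the number within the scatter of compound 3. Also open, as far as these compounds go, is how a hydroxamic acid or an amine at the chain end would compare with the sulfanyl end.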